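Compound 3: trifluoromethyl in place of hydrogen

The compounds below may be only part of what the source reports. "The series", "measured", "known", "first", "only" and "open" are said of these compounds alone.

Measured so far in a functional assay on CAKI-1 cells (Homo sapiens) for inhibition, read by sulforhodamine B assay, with a stated time of 48 h, tested at 0.01 uM; on this read-out lower numbers stand for a stronger effect and higher numbers for a weaker effect at the one concentration tested:
- compound 1 `COc1cc(Cl)cc(-c2nn(-c3cccc(NC(=O)Nc4cccc(C(F)(F)F)c4)c3)cc2-c2ccncc2)c1` gives 102%
- compound 2 `COc1cc(Cl)cc(-c2nn(-c3cccc(NC(=O)Nc4ccc(Cl)c(C(F)(F)F)c4)c3)cc2-c2ccncc2)c1` gives 98%

Among the measured compounds shown here, compound 1 stands highest of the two numbers in this assay, with compound 2 nearest, and the one step that joins them, a number 4 percentage points lower from compound 1 to compound 2 (within the scatter), is within the scatter. Both numbers sit at the level of no inhibition at the single concentration tested.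

Compound 3 `COc1cc(Cl)cc(-c2nn(-c3cccc(NC(=O)Nc4cc(C(F)(F)F)cc(C(F)(F)F)c4)c3)cc2-c2ccncc2)c1` is not yet measured. It differs from compound 1 by trifluoromethyl in place of hydrogen on an aromatic carbon. For the measured compounds named here, no measured step covers this exact change; the only step on the same ring, a number 4 percentage points lower from compound 1 to compound 2 (within the scatter), also adds a small group onto an aromatic carbon and moves the read-out not at all beyond the scatter. On that basis no step beyond the scatter is expected in this assay for compound 3, in either direction: the expected step is a number 2 percentage points lower from compound 1 to compound 3 (within the scatter).

Compound 3 is therefore estimated at 100% in this assay, with a range from 90% to 110%.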

Compound 3, a percentage reported as activity, at one concentration (the size of the read-out at that concentration, not a potency): 97%
Compound 3: the middle estimate sits 3 percentage points above what was measured; the range from low to high includes it.
By their numbers in this assay, from the lowest: compounds 3, 2 and 1 (each within the scatter of the next).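

In this assay, placing a second trifluoromethyl group on an aromatic carbon, meta to the trifluoromethyl group already present, gives (a number 5 percentage points lower from compound 1 to compound 3 (within the scatter)), so this position accepts a group of 4 heavy atoms with no shift beyond the scatter. The earlier step (a number 4 percentage points lower from compound 1 to compound 2 (within the scatter)) covered only chloro, so the flat response on this ring now extends to a second, larger substituent at another carbon, and compound 3 at (97%) remains at the level of no inhibition at the single concentration tested. No measured evidence bears on why the read-out stays level across this change.

Whether this carbon would respond to an amine, a carboxylic acid or a longer chain remains open, since the groups shown here are limited to chloro and trifluoromethyl. Also open, on these data alone, is whether compound 1 and compound 3 would separate at a higher concentration, as a read-out at one low concentration gives no potency for either.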